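The compounds below may be only part of what the source reports. "The series", "measured", "known", "first", "only" and "open" are said of these compounds alone.

Measured so far:
- compound 1 `COc1ccc(-c2nc(SCC(=O)c3sc(-c4ccccc4)nc3C)[nH]c(=O)c2C#N)cc1`, in a functional assay on U-87MG ATCC cells for antiproliferative activity against U-87 MG (Homo sapiens), read by MTT assay, with a stated time of 48 h, tested at 10 uM (on this read-out higher numbers stand for a weaker effect at the one concentration tested and lower numbers for a stronger effect), compound 1 gives 90.4%
- compound 2 `Cc1nc(-c2ccc(Cl)cc2)sc1C(=O)CSc1nc(-c2ccc(Cl)c(Cl)c2)c(C#N)c(=O)[nH]1`, in this assay compound 2 gives 97.1%

Both numbers sit high on this read-out, which means a weak effect at the single concentration used. Compound 2 holds the higher of the two figures on paper, yet its gap to compound 1 lies within the scatter, so the two compounds read alike and neither stands apart.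

The next compound is compound 3 `Cc1nc(-c2ccccc2)sc1C(=O)CSc1nc(-c2ccc(Cl)c(Cl)c2)c(C#N)c(=O)[nH]1`. Compared with compound 2 the change is hydrogen in place of chloro on an aromatic carbon; cut one bond further out it reads 4-chlorophenyl to phenyl, on a six-membered aromatic ring of carbon only, para to a large group.

Going by the values given here, no step between measured compounds is available to calibrate this change. With both measured compounds reading alike and weak, the step from compound 2 to compound 3 is expected to be a number 4.1 percentage points lower from compound 2 to compound 3 (within the scatter), none beyond the scatter in either direction. Compound 3 is therefore estimated at 93%, in a range from 80% to 102%.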

Compound 3, a percentage reported as activity, at one concentration (the size of the read-out at that concentration, not a potency): 92.5%
Compound 3: the middle estimate sits 0.5 percentage points above what was measured, within the range that was stated.
By their numbers in this assay, from the lowest: compounds 1, 3 and 2 (each within the scatter of the next).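

In this assay, going from the 4-chlorophenyl to the phenyl group gives a number 4.6 percentage points lower from compound 2 to compound 3 (within the scatter) and so this position, on a six-membered aromatic ring of carbon only, para to a large group, shows no readable response to hydrogen in place of chloro at the one concentration tested. At the other aryl group, 3,4-dichlorophenyl in place of 4-methoxyphenyl gives a number 2.1 percentage points higher from compound 1 to compound 3 (within the scatter) and so that site also shows no readable response, with all three compounds still reading as weak. Nothing measured here accounts for either step or for the weak effect across these compounds.

The compounds shown leave open whether a different group at this position, such as an amine, a carboxylic acid or a longer alkyl chain in place of the chloro, would move the number beyond the scatter. Also open, on these data alone, is whether changing a part of the shared core, such as replacing the nitrile with a carboxylic acid, would give a stronger effect in this assay at the same concentration.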